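A few compounds are considered here, and "the series" means these few. Any claim that something is new, unique, unknown or untested is made for them only; others in the source may bear on it.

Compound 2 `COc1ccc(/C=C/C(=O)c2ccc(OC)c3c2OC(C)(C)C=C3)cc1OCCO` carries a 2-hydroxyethyl group on an oxygen on an aromatic ring of the shared core. In a functional assay on HepG2 cells (Homo sapiens) for cytotoxicity, read by MTT assay (a higher number here means a weaker inhibitor, a lower number a stronger inhibitor), compound 2 reaches only a limit, > 10000 nM. Compound 1 `C#CCOc1cc(/C=C/C(=O)c2ccc(OC)c3c2OC(C)(C)C=C3)ccc1OC`, with propargyl on that oxygen, likewise gives only a limit, > 10000 nM. Hence a step that the two limits leave unreadable from compound 1 to compound 2. Compound 3 `COc1ccc(/C=C/C(=O)c2ccc(OC)c3c2OC(C)(C)C=C3)cc1OC(=O)c1ccc(Br)cc1`, with (4-bromophenyl)carbonyl there, gives a number in this assay, 680 nM; this makes an at least 14-fold lower number from compound 2 to compound 3 (1.16 log units; beyond the scatter) and an at least 14-fold lower number from compound 1 to compound 3 (1.16 log units; beyond the scatter), both starting at the limit of > 10000 nM in this assay, at which 2 of the 3 values shown sit. Compound 4 `COc1ccc(/C=C/C(=O)Oc2cc(/C=C/C(=O)c3ccc(OC)c4c3OC(C)(C)C=C4)ccc2OC)cc1` differs from compound 2 by (2-(4-methoxyphenyl)ethenyl)carbonyl in place of 2-hydroxyethyl on an oxygen on an aromatic ring, again a carbonyl-linked aromatic group on that oxygen. A drop of similar size is expected because an at least 14-fold lower number from compound 2 to compound 3 (1.16 log units; beyond the scatter) came from the closest change, so an at least 11-fold lower number from compound 2 to compound 4 (1.04 log units; beyond the scatter) is estimated. For compound 4 the estimate is 900 nM, between 250 nM and 5000 nM.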

Compound 4, half-maximal inhibitory concentration: 430 nM
Compound 4: middle estimate off by 2.1-fold (0.32 log units), on the high side, within the range that was stated.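

In this assay, a second carbonyl-linked aromatic group on the oxygen on an aromatic ring also gives a real number, with an at least 23-fold lower number from compound 2 to compound 4 (1.36 log units; beyond the scatter) and an at least 23-fold lower number from compound 1 to compound 4 (1.36 log units; beyond the scatter). Both of these steps start from a limit: the limit of > 10000 nM in this assay, at which 2 of the 4 values shown sit.

Exchanging 4-bromophenyl for 2-(4-methoxyphenyl)ethenyl on the carbonyl carbon gives a 1.6-fold lower number from compound 3 to compound 4 (0.20 log units; within the scatter), so compound 3 and compound 4 cannot be told apart.

Still open, going by these compounds, is whether the carbonyl or the aromatic ring it carries matters. An acetyl group or a benzyl group on that oxygen would separate the two.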